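The source may hold more compounds than are shown below. What is called first, only, known or untested is meant among the compounds shown, and "the series" means these compounds.

Measured compounds in this series:

compound 1, `N/C(=N\NC(=S)N1CCCCCC1)c1ccccn1`: 67%
compound 2, `N/C(=N\NC(=S)N1CCOCC1)c1ccccn1`: 26.8%
compound 3, `Cc1cccc(/C(N)=N/NC(=S)N2CCOCC2)n1`: 30.2%

In a functional assay on A-375 cells (Homo sapiens) for cytotoxicity, read by MTT assay, with a stated time of 72 h, tested at 1 uM (a lower number here means less inhibition of growth, a higher number more inhibition of growth at the concentration tested), compound 1 gives 67% and stands highest of the three measured numbers. Its nearest neighbour is compound 3, and that gap, like the gap to compound 2, lies beyond the usual scatter. Compound 1 and compound 2 differ in more than one place, so the difference between the two cores is not broken down here.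

Within the core of compound 2, the change to compound 3 is methyl in place of hydrogen on an aromatic carbon. The step this made in this assay is a number 3.4 percentage points higher from compound 2 to compound 3 (within the scatter), so it lies within the scatter and gives no sign of a real shift.

Compound 4, `Cc1ccnc(/C(N)=N/NC(=S)N2CCCCCC2)c1`, is not yet measured. It differs from compound 1 by methyl in place of hydrogen on an aromatic carbon. Among the measured compounds shown here, this is the same kind of change as the one from compound 2 to compound 3, but not the same: in compound 3 the methyl sits next to the ring nitrogen, meta to a large group, whereas in compound 4 it sits meta to a large group, opposite the ring nitrogen. Both changes occur on a different core.

For the measured compounds named here, the only guide available is the step from compound 2 to compound 3, which was within the scatter. On that basis the step from compound 1 to compound 4 is expected to be small as well, a number 2 percentage points lower from compound 1 to compound 4 (within the scatter), because a number 3.4 percentage points higher from compound 2 to compound 3 (within the scatter) gave no shift beyond the scatter. Compound 4 is therefore estimated at 65% in this assay, with a range from 45% to 82%; the wider range reflects that the place of the methyl and the core both differ from the measured pair.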

Compound 4, percent growth inhibition at one concentration: 61.9%
The estimate for compound 4 lay 3.1 percentage points above the measured number; the measured number falls inside the stated range.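

In this assay, methyl in place of hydrogen on an aromatic carbon gives a second small step on the other core, a number 5.1 percentage points lower from compound 1 to compound 4 (within the scatter). Set beside the earlier step, the same change shows no difference between the two cores that can be told from the scatter: the same change on two cores in this assay, a number 3.4 percentage points higher (within the scatter) from compound 2 to compound 3 and a number 5.1 percentage points lower (within the scatter) from compound 1 to compound 4, 8.5 percentage points apart, within the scatter of two such steps. This supports treating the methyl as a change that leaves the number within the scatter on both cores in this assay at the one concentration tested, but it does not show that the cores respond alike or that the place of the methyl is without consequence: the methyl of compound 4 sits meta to a large group, opposite the ring nitrogen, the methyl of compound 3 sits elsewhere, and the two steps change core and place together.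

Open, going by these compounds, is how each place of the methyl behaves on the other core, which would separate the place from the core. Also open, on these data alone, is whether a group other than methyl on the same aromatic ring, such as trifluoromethyl, methoxy or an amine, gives a step beyond the scatter.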